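The source may hold more compounds than are shown below. What is called first, only, known or untested is meant among the compounds shown, and "the series" means these compounds.

Measured compounds:
- Compound 1, `CC(=O)NS(=O)(=O)c1ccc(N/C(S)=N\c2ccnc3cc(C(F)(F)F)ccc23)cc1`: in a functional assay on MDA-MB-231 cells (Homo sapiens) for antiproliferative activity, read by sulforhodamine B assay, with a stated time of 48 h (a lower number here means a stronger inhibitor, a higher number a weaker inhibitor), compound 1 gives 58600 nM
- Compound 2, `N=C(N)NS(=O)(=O)c1ccc(N/C(S)=N\c2ccnc3cc(C(F)(F)F)ccc23)cc1`: compound 2 is reported as "not active" (no number reported), without a number
- Compound 3, `Cc1ccnc(NS(=O)(=O)c2ccc(N/C(S)=N\c3ccnc4cc(C(F)(F)F)ccc34)cc2)n1`: compound 3 gives 29800 nM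

All three share one core and differ only in the group on the sulfonamide nitrogen. Among the two compounds with a number, compound 3 carries the lower one, but the single step that connects them, a 2.0-fold lower number from compound 1 to compound 3 (0.29 log units; within the scatter), does not rise above the scatter, so the two cannot be ranked against each other.

Compound 4, `Cc1cc(C)nc(NS(=O)(=O)c2ccc(N/C(S)=N\c3ccnc4cc(C(F)(F)F)ccc34)cc2)n1`, is the next member. Compared with compound 3 the change is methyl in place of hydrogen on an aromatic carbon. For the measured compounds named here, no measured pair shows what adding a methyl to this ring does; the only step on record, from compound 1 to compound 3, swaps the whole group on the sulfonamide nitrogen and still stays within the scatter. Against that background the expected step of a 1.0-fold higher number from compound 3 to compound 4 (0.00 log units; within the scatter) is none beyond the scatter. Compound 4 is therefore expected to come in near 30000 nM, with a range from 10000 nM to 90000 nM.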

Compound 4, half-maximal inhibitory concentration: 52900 nM
Compound 4: the middle estimate sits 1.8-fold (0.25 log units) below what was measured; the measured number falls inside the stated range.
By their numbers in this assay, from the lowest: compounds 3, 4 and 1 (each within the scatter of the next).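

Placing a methyl on this aromatic carbon, which turns 4-methylpyrimidin-2-yl into 4,6-dimethylpyrimidin-2-yl, gives a 1.8-fold higher number from compound 3 to compound 4 (0.25 log units; within the scatter) in this assay and so offers the first measured look at this position, where this small addition makes no difference that can be told from the scatter. Putting 4,6-dimethylpyrimidin-2-yl in place of acetyl on the sulfonamide nitrogen gives a 1.1-fold lower number from compound 1 to compound 4 (0.04 log units; within the scatter) and so also stays within the scatter, as the swap to 4-methylpyrimidin-2-yl did. No measurement at hand accounts for these results.

The compounds shown leave open whether a different group on this carbon, such as an amine, a carboxylic acid or a longer chain, would shift the number beyond the scatter. They also leave open what the ring would give with no methyl on it at all.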